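Swapping cyclohex-1-en-1-yl for pyridin-3-yl

The source may report more compounds than this note shows. Statements on the series, on what has been measured and on what is new or still open speak of the compounds shown alone.

- compound 1 `CCN(c1ccc(C#N)c(Cl)c1)c1cc(-c2ccco2)ccc1C` gives > 30000 nM as a limit, not a number
- compound 2 `CCN(c1ccc(C#N)c(Cl)c1)c1cc(-c2ccc(F)nc2)ccc1C` gives > 30000 nM as a limit, not a number
- compound 3 `CCN(c1ccc(C#N)c(Cl)c1)c1cc(C2=CCCCC2)ccc1C` gives 20000 nM as a measured number

These values come from a functional assay on VCaP cells (Homo sapiens) for antiproliferative activity, read by CCK-8 assay, with a stated time of 6 days (a higher number here means a weaker inhibitor, a lower number a stronger inhibitor), and compound 3 is the only one of the three with a real number. The rest of the picture is the limit of > 30000 nM in this assay, at which 2 of the 3 values shown sit, and so offers no number for comparison.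

Compound 4 `CCN(c1ccc(C#N)c(Cl)c1)c1cc(-c2cccnc2)ccc1C` carries pyridin-3-yl in place of cyclohex-1-en-1-yl on an aromatic carbon and so has a six-membered aromatic ring with 1 hetero atom at that spot.

Among the measured compounds shown here, two measured steps bear on this change. They are an at least 1.5-fold lower number from compound 2 to compound 3 (0.17 log units; that floor lies within the scatter) and an at least 1.5-fold lower number from compound 1 to compound 3 (0.17 log units; that floor lies within the scatter) and both end at cyclohex-1-en-1-yl, starting from the aromatic groups 6-fluoropyridin-3-yl and furan-2-yl. Neither step is shown to exceed the scatter, so no step clearly beyond the scatter is expected here, although a higher number seems the likelier direction. The estimated step is a 1.5-fold higher number from compound 3 to compound 4 (0.18 log units; within the scatter) and it is only a tentative expectation. For compound 4 the estimated value is 30000 nM with an expected range from 13000 nM to 70000 nM and the assay may well report only a limit.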

Compound 4, half-maximal inhibitory concentration: 1270 nM
Estimate against measurement, compound 4: 24-fold (1.37 log units) above, and the stated range ends above it.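

In this assay, among the compounds shown here, this position turns out to be highly sensitive to the exact ring it carries, which the earlier compounds could not show: pyridin-3-yl in place of cyclohex-1-en-1-yl gives a 16-fold lower number from compound 3 to compound 4 (1.20 log units; beyond the scatter). An aromatic ring alone is not enough, as pyridin-3-yl in place of furan-2-yl gives an at least 23-fold lower number from compound 1 to compound 4 (1.37 log units; beyond the scatter). Even one atom on the ring counts, since hydrogen in place of fluoro gives an at least 23-fold lower number from compound 2 to compound 4 (1.37 log units; beyond the scatter), and this step and the one before it are only floors, because their starting compounds each give a limit rather than a number: the limit of > 30000 nM in this assay, at which 2 of the 4 values shown sit.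

The compounds shown leave open whether the ring nitrogen itself matters, which a plain phenyl ring at this spot would test, and whether its place in the ring matters, which pyridin-4-yl would test. They also leave open whether the loss seen with fluoro is particular to that atom or would also appear with another small group on the same carbon of the pyridine ring, such as methyl or methoxy.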